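Amide substituent exchange on a B1 bradykinin antagonist scaffold

This account rests on a few compounds, and the source may have more. Where it says the series, first, only, none or still open, it means among the compounds named here.

Measured so far, in an in vitro functional assay on cells for antagonist activity at B1 bradykinin receptor (Homo sapiens), read by luminescence and calcium flux, with a stated time of 2 h; on this read-out higher numbers stand for weaker inhibition and lower numbers for stronger inhibition:
- compound 1 `Cc1ccc(S(=O)(=O)N2C=CNC(=O)[C@H]2CC(=O)N[C@@H]2CCc3ccccc32)cc1` gives 94.7 nM
- compound 2 `COc1ccc2c(c1)C(NC(=O)C[C@@H]1C(=O)NC=CN1S(=O)(=O)c1ccc(C)cc1)CCC2` gives 178 nM
- compound 3 `Cc1ccc(S(=O)(=O)N2C=CNC(=O)[C@H]2CC(=O)N[C@@H]2CCC(O)c3ccccc32)cc1` gives 1.47 nM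

Compound 1 sits second highest of the three numbers in this assay. Its nearest neighbour is compound 2, whose number is higher but within the scatter, so the two cannot be ordered. Compound 3 is the furthest, with a much lower number that lies well beyond the scatter; compound 3 is the clearly strongest inhibitor of the three.

The step under consideration goes from compound 1 to compound 4 `Cc1ccc(S(=O)(=O)N2C=CNC(=O)[C@H]2CC(=O)NC2CCOCC2(C)C)cc1`. The change is a group of 8 heavy atoms (7 carbon, 1 oxygen; one six-membered non-aromatic ring with 1 hetero atom) in place of a group of 9 heavy atoms (9 carbon; one five-membered non-aromatic ring of carbon only, one six-membered aromatic ring of carbon only), on an amide-type nitrogen. Among the measured compounds shown here, no measured pair covers this exchange, so the size of the step is open. Since every measured compound carries an aromatic ring in this position, and the sole large gain seen, from compound 1 to compound 3 with 1.47 nM, kept that ring, the expectation is a move toward weaker inhibition, a 4.8-fold higher number from compound 1 to compound 4 (0.68 log units; beyond the scatter), of a size beyond the scatter. Compound 4 is estimated at 450 nM, within a range of 100 nM to 2500 nM.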

Compound 4, half-maximal inhibitory concentration: 25.2 nM
Compound 4: the middle estimate sits 18-fold (1.25 log units) above what was measured, outside the stated range (below it).
By their numbers in this assay, from the lowest: compound 3; then compound 4; then compounds 1 and 2 (each within the scatter of the next).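

In this assay, replacing the 2,3-dihydro-1H-inden-1-yl group on the amide-type nitrogen with a six-membered non-aromatic ring with one hetero atom gives a 3.8-fold lower number from compound 1 to compound 4 (0.57 log units; beyond the scatter), a modest gain in inhibition. Among the compounds shown here, compound 4 is the only one of the four compounds without an aromatic ring in this place, so at least on the core of compound 1, such a ring is not required for inhibition, and a smaller group with an oxygen in its ring can do better than the 2,3-dihydro-1H-inden-1-yl group. Nothing available on these compounds accounts for the gain.

The exchange alters the ring type, the ring size and the atom make-up together, so a single pair cannot assign the step to any one of these features. On these data alone, a cyclohexyl group would test whether the ring oxygen matters, a piperidine would show how an amine is taken at this place, and the effect of the two methyl groups on the new ring remains open as well.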